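A few compounds are considered here, and "the series" means these few. Any claim that something is new, unique, unknown or untested is made for them only; others in the source may bear on it.

Compound 2 `CCC(C)(C)Cc1c[nH]c(CCc2ccc(-c3csnn3)cc2)n1` gives 109 nM in a functional assay on HEK293 cells for agonist activity at Bombesin receptor subtype-3 (Mus musculus), read by luminescence and calcium flux, with a stated time of 10 min (on this read-out higher numbers stand for an effect only at larger amounts of compound and lower numbers for an effect already at smaller amounts), and compound 1 `CCC(C)(C)Cc1c[nH]c(CCc2ccc(-n3ccnn3)cc2)n1` gives 111 nM in this assay; the two numbers sit side by side, as a 1.0-fold lower number from compound 1 to compound 2 (0.01 log units; within the scatter) shows. Compound 3 `CCC(C)(C)Cc1c[nH]c(CCc2ccc(N3CCCCC3)cc2)n1` carries piperidin-1-yl in place of 1,2,3-thiadiazol-4-yl on an aromatic carbon. Within the data shown here, the only measured step, from compound 1 to compound 2, exchanged one five-membered aromatic ring for another and stayed within the scatter, so no measured step speaks to a six-membered non-aromatic ring at this position. Compound 3 is therefore expected near compound 2, at 150 nM (range 40 nM to 600 nM), with a 1.4-fold higher number from compound 2 to compound 3 (0.14 log units; within the scatter) as the expected step.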

Compound 3, half-maximal effective concentration: 133 nM
Compound 3: the middle estimate sits 1.1-fold (0.05 log units) above what was measured, within the range that was stated.
By their numbers in this assay, from the lowest: compounds 2, 1 and 3 (each within the scatter of the next).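

On an aromatic carbon para to a large group, the series now extends from five-membered aromatic rings to a six-membered non-aromatic ring: piperidin-1-yl in place of 1,2,3-thiadiazol-4-yl (a 1.2-fold higher number from compound 2 to compound 3 (0.09 log units; within the scatter)) and in place of 1H-1,2,3-triazol-1-yl (a 1.2-fold higher number from compound 1 to compound 3 (0.08 log units; within the scatter)) both stay within the scatter. Across these three compounds, neither ring size nor aromatic character separates the numbers. Nothing on hand bears on why these groups read alike. Open, as far as these compounds go, is whether a carboxylic acid, a primary amine or a longer alkyl chain here would move the number beyond the scatter.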